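The compounds below may be only part of what the source reports. "The series", "measured", "known", "first", "only" and "open" are said of these compounds alone.

Of the compounds shown here, two have been measured in a functional assay for binding affinity to metabotropic glutamate receptor 2 (Homo sapiens), read by GTPgammaS binding; a higher number here means that more compound is needed for the effect, a lower number that less compound is needed. Compound 1 `CC(C)CC(=O)c1ccc(OCCCCOc2cccc(F)c2F)c(Br)c1O` gives 558 nM, and compound 2 `Cc1c(OCc2ccc(CSc3ccncc3)cc2)ccc(C(=O)CC(C)C)c1O` gives 770 nM; these two numbers sit within the usual scatter of each other, so neither compound can be called more or less potent than the other. Compound 3 `Cc1c(OCc2ccc(Sc3ccncc3)cc2)ccc(C(=O)CC(C)C)c1O` differs from compound 2 in one place: (pyridin-4-yl)sulfanyl in place of ((pyridin-4-yl)sulfanyl)methyl on an aromatic carbon. For the measured compounds named here, no measured pair shows a comparable change, so there is no step to lean on, and a shift in either direction is conceivable. With nothing pointing one way, the expected step from compound 2 to compound 3 is a 1.0-fold higher number from compound 2 to compound 3 (0.02 log units; within the scatter). Compound 3 is therefore estimated at 800 nM, within 300 nM to 2200 nM.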

Compound 3, half-maximal effective concentration: 1060 nM
For compound 3 the middle estimate is 1.3-fold (0.12 log units) below the measured one; the range from low to high includes it.
By their numbers in this assay, from the lowest: compounds 1, 2 and 3 (each within the scatter of the next).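

In this assay, putting (pyridin-4-yl)sulfanyl in place of ((pyridin-4-yl)sulfanyl)methyl on this aromatic carbon gives a 1.4-fold higher number from compound 2 to compound 3 (0.14 log units; within the scatter). This first one-place comparison shows that, for this pair, the shorter group leaves the number within the usual scatter, so this change has no readable effect. No measurement at hand offers a reason for this result. Still open, from the compounds shown here alone, is whether a different group at this position, such as an amine, a carboxylic acid or a longer chain, would shift the number beyond the scatter.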